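Isopropyl in place of fluoro on the methoxy-bearing compound

The source may report more compounds than this note shows. Statements on the series, on what has been measured and on what is new or still open speak of the compounds shown alone.

Going by the values given here, compound 3 `COc1ccc2nc(C3CC3)c(/C=C/[C@@H]3C[C@@H](O)CC(=O)O3)c(Sc3ccc(F)cc3)c2c1` gives 25700 nM in an assay on isolated protein for inhibition of 3-hydroxy-3-methylglutaryl-coenzyme A reductase (Homo sapiens), read by spectrophotometry (on this read-out higher numbers stand for weaker inhibition and lower numbers for stronger inhibition), and stands second highest of the three numbers measured so far. Compound 1 `O=C1C[C@H](O)C[C@@H](/C=C/c2c(C3CC3)nc3ccccc3c2Sc2ccc(F)cc2)O1` gives 62400 nM, and compound 2 `CC(C)c1ccc(Sc2c(/C=C/[C@@H]3C[C@@H](O)CC(=O)O3)c(C3CC3)nc3ccccc23)cc1` gives 11300 nM, so on the numbers compound 3 lies between the two. Compound 4 `COc1ccc2nc(C3CC3)c(/C=C/[C@@H]3C[C@@H](O)CC(=O)O3)c(Sc3ccc(C(C)C)cc3)c2c1` has not been measured; it differs from compound 3 by isopropyl in place of fluoro on an aromatic carbon. The same change has been run once already in this series, on a different starting point, and there it read a 5.5-fold lower number from compound 1 to compound 2 (0.74 log units; beyond the scatter). The other measured step, a 2.4-fold lower number from compound 1 to compound 3 (0.39 log units; beyond the scatter), is the change that produces compound 3 itself and does not bear directly on the present substitution. On that single precedent the expected step in this assay is one in the same direction, lower and beyond the scatter, of about a 5.5-fold lower number from compound 3 to compound 4 (0.74 log units; beyond the scatter). For compound 4 the estimated number in this assay is therefore 4700 nM, with a range of 2000 nM to 11000 nM.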

Compound 4, half-maximal inhibitory concentration: 41300 nM
Compound 4: the middle estimate sits 8.8-fold (0.94 log units) below what was measured; measured number above the stated range.
By their numbers in this assay, from the lowest: compound 2; then compounds 3, 4 and 1 (each within the scatter of the next, the first and the last beyond it).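

In this assay, the change from 4-fluorophenyl to 4-isopropylphenyl on the methoxy-bearing core gives a 1.6-fold higher number from compound 3 to compound 4 (0.21 log units; within the scatter), so the gain seen on the core without methoxy does not carry over to this core: the same change on two cores in this assay, a 5.5-fold lower number (0.74 log units; beyond the scatter) from compound 1 to compound 2 and a 1.6-fold higher number (0.21 log units; within the scatter) from compound 3 to compound 4, 8.9-fold (0.95 log units) apart, beyond the scatter of two such steps. Read the other way, the methoxy change also depends on its partner group, giving a 3.7-fold higher number from compound 2 to compound 4 (0.56 log units; beyond the scatter) with isopropyl present, against the opposite direction with fluoro present: the same change on two cores in this assay, a 2.4-fold lower number (0.39 log units; beyond the scatter) from compound 1 to compound 3 and a 3.7-fold higher number (0.56 log units; beyond the scatter) from compound 2 to compound 4, 8.9-fold (0.95 log units) apart, beyond the scatter of two such steps. The two changes therefore do not add across these four compounds, and compound 2, with isopropyl and no methoxy, has the lowest number of the set.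

One set of four compounds cannot show whether this dependence is particular to isopropyl and methoxy. Chloro or tert-butyl in place of the fluoro, on both cores, would test that, as would an ethoxy in place of the methoxy.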